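Chloro for Methoxy at the Edge of Measurement

This account rests on a few compounds, and the source may have more. Where it says the series, first, only, none or still open, it means among the compounds named here.

Compound 1 `COc1ccc(S(=O)(=O)Nc2ccc(-c3nc4ccccc4o3)cc2)cc1` carries a methoxy on the phenyl joined to the sulfonyl sulfur. In an assay on isolated protein for inhibition of malate dehydrogenase, mitochondrial (Sus scrofa), with stated times of 45 min and 30 min (a higher number here means a weaker inhibitor, a lower number a stronger inhibitor), compound 1 gives only a limit, > 63000 nM. Two other compounds were measured alongside it. Compound 2 `O=S(=O)(Nc1ccc2oc(-c3ccccc3)nc2c1)c1cccc(O)c1` gives in this assay a limit as well, > 63000 nM. Compound 3 `COc1ccc(S(=O)(=O)Nc2ccc3oc(-c4ccccc4)nc3c2)cc1` likewise gives in this assay a limit, > 63000 nM. The single change measured among these, a step that the two limits leave unreadable from compound 2 to compound 3, cannot be read as a step because of the limit of > 63000 nM in this assay, at which 3 of the 3 values shown sit. Compound 4 `O=S(=O)(Nc1ccc(-c2nc3ccccc3o2)cc1)c1ccc(Cl)cc1` differs from compound 1 by chloro in place of methoxy on an aromatic carbon. Among the compounds with values here, no measured step bears directly on this change, and since every value shown sits at the limit, the data cannot say whether chloro in place of methoxy moves inhibition beyond the scatter in either direction. Compound 4 is therefore expected to remain at or near that limit, with a step that the limit leaves unreadable from compound 1 to compound 4 expected to be no real movement. The estimate for compound 4 is 80000 nM, expected to lie between 30000 nM and 300000 nM.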

Compound 4, half-maximal inhibitory concentration: > 63000 nM
Compound 4: a limit, no number; the forecaster's own chance of this, stated with the estimate: 85%; the middle value lies beyond the limit too.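

No step can be read between compound 1 and compound 4, because both give only a limit: the limit of > 63000 nM in this assay, at which 4 of the 4 values shown sit. The compounds shown leave open how strongly any of them inhibits the enzyme, and whether chloro in place of methoxy changes inhibition at all.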